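This account rests on a few compounds, and the source may have more. Where it says the series, first, only, none or still open, it means among the compounds named here.

Working notes on the series. Within the data shown here, compound 1 `Cc1ncccc1-c1cnc(NCc2c(F)cc(O)c3c2CCO3)n2cnnc12` is the only member of this set with a number in hand: in an ADME assay on cells (Hepatocyte, Rattus norvegicus) for metabolic stability (a higher number here means faster removal of the compound, a lower number slower removal), compound 1 gives 50 uL/min. Among the measured compounds shown here, compound 2 `Cc1ncccc1-c1cnc(NCc2c(F)cc(C3CC3)c3c2CCO3)n2cnnc12` belongs to the same series, but in this assay compound 2 shows "not determined" (no result reported), so compound 1 has nothing to be compared against and no step between measured compounds can be drawn. Compound 3 `Cc1ncccc1-c1cnc(NCc2c(F)cc(Cl)c3c2CCO3)n2cnnc12` is not yet measured. It differs from compound 1 by a single change, (chloro in place of hydroxy on an aromatic carbon), a chloro in place of hydroxy on an aromatic carbon. For the measured compounds named here, with no measured step to rest on, the direction of the change is open; a shift in this assay is expected to be modest and may well sit within the usual scatter, with the step of a 1.2-fold higher number from compound 1 to compound 3 (0.08 log units; within the scatter) given as the working expectation. For compound 3 the estimated result in this assay is 60 uL/min, with a range from 25 uL/min to 140 uL/min.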

Compound 3, intrinsic clearance in a liver preparation (reported as CLH), per the amount of preparation that the assay uses: 9 uL/min
For compound 3 the middle estimate is 6.7-fold (0.82 log units) above the measured one, and the stated range ends above it.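

In this assay, this aromatic carbon, para to a large group, proves sensitive to substitution: chloro in place of hydroxy gives a 5.6-fold lower number from compound 1 to compound 3 (0.74 log units; beyond the scatter), a step beyond the scatter and the only readable one in the set. The change also removes the hydrogen-bond donor and acceptor counted for the hydroxy, so this position can be read as one where swapping a single heavy atom moves the number clearly. Nothing at hand explains the step or separates the departure of the hydroxy from the arrival of the chloro.

One step cannot show whether the lower number is specific to chloro or would also hold for other groups on this carbon, such as a methoxy or an amine. Any step involving compound 2 cannot be read, which leaves the cyclopropyl group at this position without a comparison.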